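Acyl aryl swap on compound 2

The compounds below may be only part of what the source reports. "The series", "measured", "known", "first", "only" and "open" are said of these compounds alone.

Compound 2, `Cc1ccc(N(C(=O)c2ccccc2C)C(=S)OCCN2C(=O)c3ccccc3C2=O)cc1`, gives in an ADME assay on MT4 cells (Homo sapiens) for cytotoxicity, read by MTT assay (a lower number here means that less compound is tolerated, a higher number that more compound is tolerated), only a limit, > 100000 nM, and so it sits at the limit of > 100000 nM in this assay, at which 1 of the 3 values shown sits. Compound 1, `Cc1ccccc1C(=O)N(C(=S)OCCN1C(=O)c2ccccc2C1=O)c1ccc(Cl)cc1`, gives 21000 nM in this assay, and the step of an at least 4.7-fold higher number from compound 1 to compound 2 (0.67 log units; beyond the scatter) is what separates the two. Compound 3, `O=C1c2ccccc2C(=O)N1CCOC(=S)N(C(=O)c1cc(F)cc(F)c1)c1ccc(Cl)cc1`, gives 59000 nM in this assay.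

Compound 4 is `Cc1ccc(N(C(=O)c2ccc(Br)c(C)c2)C(=S)OCCN2C(=O)c3ccccc3C2=O)cc1`; it differs from compound 2 only at the carbonyl carbon: 4-bromo-3-methylphenyl in place of 2-methylphenyl on a carbonyl carbon. The measured step that touches the same place is a 2.8-fold higher number from compound 1 to compound 3 (0.45 log units; beyond the scatter), where a different aromatic ring on the carbonyl carbon moved the number upward. Within the data shown here, no measured step covers a 4-bromo-3-methylphenyl group, and the change here starts from a compound that already reports only a limit. Among the measured compounds shown here, an upward step of the size seen for compound 3 would stay outside what the assay reports as a number; a downward step of comparable size would be needed to bring a number into view, and no measured step points that way. The expectation is therefore that compound 4 again reports only a limit, with a number no higher from compound 2 to compound 4 (the limit leaves the size open) as the expected step, most likely none beyond the scatter. Compound 4 is estimated at 100000 nM in this assay, within 50000 nM to 300000 nM, and a reported limit rather than a number is the more likely outcome.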

Compound 4, half-maximal cytotoxic concentration: > 100000 nM
Compound 4: a limit, no number (the forecaster's own chance of this, stated with the estimate: 70%); the middle value sits exactly at the limit.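

Compound 2 and compound 4 each report only a limit in this assay, so the step between them cannot be read. The compounds shown leave open whether 4-bromo-3-methylphenyl in place of 2-methylphenyl on a carbonyl carbon shifts the tolerated concentration at all, and in which direction.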